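Methylpyrazole in Place of Methylisothiazole on the Shared Core

A few compounds are considered here, and "the series" means these few. Any claim that something is new, unique, unknown or untested is made for them only; others in the source may bear on it.

Compound 1 `c1ccc(-c2ccsc2)c(OCC2=NCCN2)c1` carries a thiophen-3-yl group, and in a functional assay for activation of Alpha-1D adrenergic receptor (Homo sapiens), read by calcium flux (on this read-out lower numbers stand for an effect already at smaller amounts and higher numbers for an effect only at larger amounts of compound), compound 1 gives 12.6 nM. Compound 2 `c1ccc(-c2nccs2)c(OCC2=NCCN2)c1` carries a 1,3-thiazol-2-yl group in its place, and in this assay compound 2 gives 31.6 nM; the step of a 2.5-fold higher number from compound 1 to compound 2 (0.40 log units; beyond the scatter). Compound 3 `Cc1cnsc1-c1ccccc1OCC1=NCCN1` carries a 4-methyl-1,2-thiazol-5-yl group. In this assay compound 3 gives only a limit, < 100000 nM, and the limit of < 100000 nM in this assay, at which 1 of the 3 values shown sits, marks it as one. The steps a step that the limit leaves unreadable from compound 1 to compound 3 and a step that the limit leaves unreadable from compound 2 to compound 3 therefore cannot be sized. Compound 4 `Cn1nccc1-c1ccccc1OCC1=NCCN1` differs from compound 3 by 1-methyl-1H-pyrazol-5-yl in place of 4-methyl-1,2-thiazol-5-yl on an aromatic carbon. Among the measured compounds shown here, no measured step exchanges one methyl-bearing five-membered ring for another, so the only bearing evidence is that the unsubstituted rings of compound 1 and compound 2 sit far from the limit while compound 3 sits at it. Compound 4 is expected to give an estimated 1000 nM in this assay, with a range from 50 nM to 30000 nM. The expected step that the limit leaves unreadable from compound 3 to compound 4 is uncertain in direction, since compound 3 shows only a limit.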

Compound 4, half-maximal effective concentration: < 100000 nM
Compound 4: no number, only a limit; the forecaster's own chance of this, stated with the estimate: 30%; the middle value lies beyond the limit too.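

In this assay, among the compounds shown here, compound 4 gives only a limit, so no step from compound 1, compound 2 or compound 3 to compound 4 can be read: the limit of < 100000 nM in this assay, at which 2 of the 4 values shown sit.

The compounds shown leave open whether in this assay compound 3 and compound 4 differ at all, and how far either lies from compound 1 and compound 2.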